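This account rests on a few compounds, and the source may have more. Where it says the series, first, only, none or still open, it means among the compounds named here.

Compound 2 `O=C(O)[C@@H]1NC[C@H](O)[C@@H](O)[C@@H]1O` stands lowest of the two numbers measured in an assay for inhibition of alpha-N-acetylgalactosaminidase (Gallus gallus), tested at 1000 uM (on this read-out higher numbers stand for more inhibition at the one concentration tested (going by the name of the read-out) and lower numbers for less inhibition), where compound 2 gives 3.4%. Compound 1 `O=C(O)[C@H]1NC[C@H](O)[C@H](O)[C@H]1O`, its stereoisomer, gives 21% in this assay. The step of a number 17.6 percentage points lower from compound 1 to compound 2 (beyond the scatter) shows that configuration alone can shift the read-out, which follows from the fact that compounds 1 and 2 differ only in the configuration as drawn. Compound 3 `O=C(O)[C@@H]1NC[C@@H](O)[C@H](O)[C@H]1O` differs from compound 2 as follows: the two compounds have the same atoms and bonds and differ only in configuration as drawn: 3 of 4 stereo elements differ; a stereocentre at a saturated ring carbon is drawn S in compound 2 and R in compound 3; a stereocentre at a saturated ring carbon is drawn R in compound 2 and S in compound 3; a stereocentre at a saturated ring carbon is drawn R in compound 2 and S in compound 3. For the measured compounds named here, only that one configurational step bears on this change, so a step of similar size in either direction, or none beyond the scatter, is possible. The expected step is a number 6.6 percentage points higher from compound 2 to compound 3 (within the scatter). Compound 3 is estimated at 10%, ranging from 0% to 30%.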

Compound 3, a percentage reported as inhibition, at one concentration (the size of the read-out at that concentration, not a potency): 1.3%
For compound 3 the middle estimate is 8.7 percentage points above the measured one; measured number inside the range.
By their numbers in this assay, from the lowest: compounds 3 and 2 (each within the scatter of the next); then compound 1.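

In this assay, changing three stereocentres need not shift the read-out: the change gives a number 2.1 percentage points lower from compound 2 to compound 3 (within the scatter). Changing only two gives a number 19.7 percentage points lower from compound 1 to compound 3 (beyond the scatter), so among these three stereoisomers the number of centres changed does not set the size of the step, and compound 1 alone stands apart. Only configuration varies in that larger step: the fact that compounds 1 and 3 differ only in the configuration as drawn

Which single stereocentre carries the difference stays open, as each pair differs at two or three at once. Also open, going by these compounds, is how a methyl ester or an amide in place of the carboxylic acid would read out.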